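The source may hold more compounds than are shown below. What is called first, only, known or untested is meant among the compounds shown, and "the series" means these compounds.

Compound 1 `CCc1ccc2[nH]c(=O)c(CN(Cc3ccc(C(C)(C)C)cc3)[C@H](CO)c3ccccc3)cc2c1`: > 10000 nM in a toxicity assay on MDCK cells (Canis lupus familiaris) for cytotoxicity, read by crystal violet staining, with a stated time of 48 h (on this read-out higher numbers stand for lower toxicity in this test and lower numbers for higher toxicity in this test), a limit of that assay.
Compound 2 `CCc1ccc2[nH]c(=O)c(CN(Cc3ccc(C(C)(C)C)cc3)[C@H](C)c3ccc(F)cc3)cc2c1`: > 5000 nM in this assay, a limit of that assay.

Compound 2 stands at a limit in this assay, so no number is known for it. Among the compounds with values here, the only measured step, a step that the two limits leave unreadable from compound 1 to compound 2, replaces a 2-hydroxy-1-phenylethyl group with a 1-(4-fluorophenyl)ethyl group on the amine nitrogen, and because both of its ends sit at limits, the limit of > 10000 nM in this assay, at which 1 of the 2 values shown sits, and (the limit of > 5000 nM in this assay, at which 1 of the 2 values shown sits), its size cannot be read. Compound 3 `CCc1ccc2[nH]c(=O)c(CN(Cc3ccc(C(C)(C)C)cc3)C(C)c3ccc(OC)cc3)cc2c1` differs from compound 2 in one place: 1-(4-methoxyphenyl)ethyl in place of 1-(4-fluorophenyl)ethyl on an amine nitrogen. Within the data shown here, no measured step bears on this change beyond the unreadable one, so nothing points to a shift in either direction in this assay, and the expected step that the limit leaves unreadable from compound 2 to compound 3 is estimated to stay within the scatter. Compound 3 is therefore expected to give about 10000 nM, in a range from 3000 nM to 30000 nM, most likely reported again only as a limit.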

Compound 3, half-maximal cytotoxic concentration: > 5000 nM
Compound 3 gave a limit, no number; the forecaster's own chance of this, stated with the estimate: 75%; the middle value lies beyond the limit too.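

In this assay compound 3 gives only a limit, so neither step to it, from compound 1 or from compound 2, can be read: the limit of > 5000 nM in this assay, at which 2 of the 3 values shown sit. The compounds shown leave open whether changing the group on the amine nitrogen shifts this read-out at all.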